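The compounds below may be only part of what the source reports. "The series", "measured", "known", "first", "only" and "open" are said of these compounds alone.

Three close analogues were examined in an ADME assay on microsomes from liver (Homo sapiens) for metabolic stability, read by LC-MS, using NADPH, with a stated time of 30 min, tested at 1 uM; a lower number here means slower removal, a higher number faster removal of the compound. Compound 1 `C[C@H](Nc1c(C(N)=O)nnc2ccc(-c3ccc(OCCCN(C)C)nc3)cc12)C1CCOCC1` gave 28 mL.min-1.g-1 in compound 1's run of this assay. Compound 2 `C[C@H](Nc1c(C(N)=O)nnc2ccc(-c3ccc(OCCCN(C)C)nc3)cc12)c1ccn(C)n1` differs from compound 1 only in that (1-methyl-1H-pyrazol-3-yl in place of oxan-4-yl on a saturated chain carbon bound to a nitrogen on an aromatic ring and a saturated chain carbon), and compound 2 gave 10 mL.min-1.g-1. That change brought a 2.8-fold lower number from compound 1 to compound 2 (0.45 log units; beyond the scatter). Compound 3 `C[C@H](Nc1c(C(N)=O)nnc2ccc(-c3ccc(OCCCN4CCCC4)nc3)cc12)C1CCOCC1` differs from compound 1 at the other end of the molecule: pyrrolidin-1-yl in place of dimethylamino on a saturated chain carbon, three bonds along the chain from an oxygen on an aromatic ring. Compound 3 gave 23 mL.min-1.g-1, and the corresponding step was a 1.2-fold lower number from compound 1 to compound 3 (0.09 log units; within the scatter), so compound 1 and compound 3 cannot be told apart on this read-out.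

Compound 4 `C[C@H](Nc1c(C(N)=O)nnc2ccc(-c3ccc(OCCCN4CCCC4)nc3)cc12)c1ccn(C)n1` has not yet been measured. Its relation to compound 3 is that (1-methyl-1H-pyrazol-3-yl in place of oxan-4-yl on a saturated chain carbon bound to a nitrogen on an aromatic ring and a saturated chain carbon), with the change at the same place as in the pair of compound 1 and compound 2, so it is the same change carried onto the core of compound 3, where the two cores differ by pyrrolidin-1-yl in place of dimethylamino on a saturated chain carbon, three bonds along the chain from an oxygen on an aromatic ring.

The expectation for compound 4 rests on a single precedent. Because a 2.8-fold lower number from compound 1 to compound 2 (0.45 log units; beyond the scatter) was observed once on the core of compound 1, and because a 1.2-fold lower number from compound 1 to compound 3 (0.09 log units; within the scatter) shows the two cores behaving alike, the same change on compound 3 is expected to give roughly the same step, estimated as a 2.9-fold lower number from compound 3 to compound 4 (0.46 log units; beyond the scatter). On that basis compound 4 is expected to give about 8 mL.min-1.g-1 in this assay, with a likely range from 4 mL.min-1.g-1 to 16 mL.min-1.g-1; this estimate is provisional, resting on one measured pair only.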

Compound 4, intrinsic clearance in microsomes: 10 mL.min-1.g-1
Compound 4: the middle estimate sits 1.3-fold (0.10 log units) below what was measured; the measured number falls inside the stated range.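

In this assay, 1-methyl-1H-pyrazol-3-yl in place of oxan-4-yl on the core of compound 3 gave a 2.3-fold lower number from compound 3 to compound 4 (0.36 log units; beyond the scatter), and this step cannot be told apart from the one on the core of compound 1: the same change on two cores in this assay, a 2.8-fold lower number (0.45 log units; beyond the scatter) from compound 1 to compound 2 and a 2.3-fold lower number (0.36 log units; beyond the scatter) from compound 3 to compound 4, 1.2-fold (0.09 log units) apart, within the scatter of two such steps. Pyrrolidin-1-yl in place of dimethylamino gave no change at the digits printed from compound 2 to compound 4 (within the scatter), so that difference between the cores leaves no readable mark with either group present on the saturated chain carbon bound to the aromatic nitrogen: the same change on two cores in this assay, a 1.2-fold lower number (0.09 log units; within the scatter) from compound 1 to compound 3 and no change at the digits printed (within the scatter) from compound 2 to compound 4, 1.2-fold (0.09 log units) apart, within the scatter of two such steps. Together the two pairs show the change carrying over between these two cores, but they cover only dimethylamino and pyrrolidin-1-yl in a single read-out, so they do not show that it would carry to a core with a different group there, nor do they explain why the number falls.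

The compounds shown leave open whether the same step would appear with a piperidine or a morpholine in place of pyrrolidin-1-yl, or with a longer chain before the amine. They also leave open whether another aromatic ring, such as a pyridine, would give a similar step in place of 1-methyl-1H-pyrazol-3-yl.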